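Moving two chlorines on the benzyl ring

The source may report more compounds than this note shows. Statements on the series, on what has been measured and on what is new or still open speak of the compounds shown alone.

Compound 1 `NC(=O)c1c(NC(=O)c2ccccc2Cl)sc2c1CCN(Cc1ccc(Cl)cc1Cl)C2` gives 21100 nM
Compound 2 `NC(=O)c1c(NC(=O)c2ccccc2F)sc2c1CCN(Cc1c(Cl)cccc1Cl)C2` gives 33000 nM

In a functional assay on HeLa cells (Homo sapiens) for antiproliferative activity, with a stated time of 24 h (on this read-out higher numbers stand for weaker inhibition and lower numbers for stronger inhibition), compound 2 gives 33000 nM and so sits within the usual scatter of compound 1 at 21100 nM and the two numbers cannot be told apart. Compound 3 `NC(=O)c1c(NC(=O)c2ccccc2F)sc2c1CCN(Cc1ccc(Cl)cc1Cl)C2` has not yet been measured. It keeps everything in compound 2 except one group, and the change is 2,4-dichlorophenyl in place of 2,6-dichlorophenyl on a saturated chain carbon bound to an amine nitrogen in a ring which swaps 2,6-dichlorobenzyl for 2,4-dichlorobenzyl. Within the data shown here, no measured pair shows this change alone. Compound 1 also carries 2,4-dichlorobenzyl and gives 21100 nM so no step beyond the scatter is expected in this assay for this swap. The estimated step of a 1.3-fold lower number from compound 2 to compound 3 (0.12 log units; within the scatter) is therefore small and has no firm direction. For compound 3 the estimated value is 25000 nM (expected range 11000 nM to 55000 nM).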

Compound 3, half-maximal inhibitory concentration: 27500 nM
Estimate against measurement, compound 3: 1.1-fold (0.04 log units) below; low and high end bracket the measured number.
By their numbers in this assay, from the lowest: compounds 1, 3 and 2 (each within the scatter of the next).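

In this assay, the swap of 2,6-dichlorobenzyl for 2,4-dichlorobenzyl can now be read on its own, and it gives a 1.2-fold lower number from compound 2 to compound 3 (0.08 log units; within the scatter), so moving a chlorine on this ring leaves a difference that cannot be told from none. Among these compounds, the second single change, fluoro in place of chloro on an aromatic carbon, can also be read alone for the first time, and it gives a 1.3-fold higher number from compound 1 to compound 3 (0.12 log units; within the scatter), so these two compounds cannot be told apart either. No supporting data bear on why these swaps leave the numbers so close.

All three compounds keep two chlorines on the benzyl ring, so they leave open whether an amine or a carboxylic acid on that ring would give a clearly different number. As far as these compounds go, how a longer chain in place of the saturated chain carbon would read also remains open.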